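The source may hold more compounds than are shown below. What is called first, only, known or untested is meant among the compounds shown, and "the series" means these compounds.

Measured compounds:
compound 1, `CSCC[C@H](NC(=O)[C@H](CC(C)C)NC(=O)[C@H](CC(C)C)NC(=O)CC[C@H](NS(=O)(=O)c1ccc(Cl)c(C(F)(F)F)c1)C(=O)O)C(N)=O`: in an assay on isolated protein for inhibition of Matrilysin (Homo sapiens), read by fluorescence, with a stated time of 15 min (on this read-out higher numbers stand for weaker inhibition and lower numbers for stronger inhibition), compound 1 gives 780 nM.
compound 2, `CSCC[C@H](NC(=O)[C@H](CC(C)C)NC(=O)[C@H](C)NC(=O)CC[C@H](NS(=O)(=O)c1ccc(Cl)c(C(F)(F)F)c1)C(=O)O)C(N)=O`: in this assay compound 2 gives 440 nM.

Compound 2 holds the lower of the two numbers, but the step between the two is a 1.8-fold lower number from compound 1 to compound 2 (0.25 log units; within the scatter), so the two values are not separated beyond the scatter. Compound 3, `CSCC[C@H](NC(=O)[C@H](CC(C)C)NC(=O)[C@H](CCC(N)=O)NC(=O)CC[C@H](NS(=O)(=O)c1ccc(Cl)c(C(F)(F)F)c1)C(=O)O)C(N)=O`, takes the following step from compound 2: carbamoylmethyl in place of hydrogen on a saturated chain carbon, two bonds along the chain from an amide-type nitrogen and a carbonyl carbon. Among the measured compounds shown here, the only measured step touching that chain carbon is the one in which isopropyl gave way to hydrogen, a 1.8-fold lower number from compound 1 to compound 2 (0.25 log units; within the scatter); it shows that taking away a side chain at this carbon left the number essentially where it was. The present change puts a different side chain, carbamoylmethyl, onto the same carbon. With a single step to go on, and that step within the scatter, no movement beyond the scatter is expected in this assay for compound 3; a step of a 1.1-fold higher number from compound 2 to compound 3 (0.06 log units; within the scatter) is the working expectation. Compound 3 is estimated at 500 nM, with a range of 200 nM to 1300 nM.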

Compound 3, half-maximal inhibitory concentration: 1300 nM
Compound 3: middle estimate off by 2.6-fold (0.41 log units), on the low side; measured number inside the range.
By their numbers in this assay, from the lowest: compounds 2, 1 and 3 (each within the scatter of the next, the first and the last beyond it).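

In this assay this chain carbon now gives a step beyond the scatter: carbamoylmethyl in place of hydrogen reads as a 3.0-fold higher number from compound 2 to compound 3 (0.47 log units; beyond the scatter) and is modest in size, whereas the earlier step at this carbon, isopropyl to hydrogen, stayed within the scatter. Carbamoylmethyl in place of isopropyl on the same carbon reads as a 1.7-fold higher number from compound 1 to compound 3 (0.22 log units; within the scatter) so these two side chains are not separated here, and compound 2 is separated from compound 3 but not from compound 1, which leaves the position only weakly resolved on three compounds. Nothing available bears on what lies behind the step at this carbon.

Open, from the compounds shown here alone, is whether carbamoylmethyl stands for side chains of its kind or only for itself: a carboxylic acid or an amine carried on a chain at this carbon would test that directly. A longer chain ending in the same primary amide, or a hydroxymethyl group, would also show whether the number follows the length of the side chain or the group at its end.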